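The source may hold more compounds than are shown below. What is called first, only, known or untested is meant among the compounds shown, and "the series" means these compounds.

In a functional assay on MCF7 cells (Homo sapiens) for inhibition, read by sulforhodamine B assay, with a stated time of 48 h (on this read-out lower numbers stand for stronger inhibition of growth and higher numbers for weaker inhibition of growth), compound 1 `COc1ccc(/C=C/C2(C)C=CC(=O)O2)c(OC)c1` gives 43500 nM and compound 2 `COc1ccc(/C=C/C2(C)C=CC(=O)O2)c(OC)c1OC` gives 110000 nM, the higher of the two numbers and so the weaker inhibition of growth. For the measured compounds named here, the only measured step, a 2.5-fold higher number from compound 1 to compound 2 (0.40 log units; beyond the scatter), is methoxy in place of hydrogen on an aromatic carbon. It is modest but beyond the scatter.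

Compound 3 `COc1c(O)ccc(/C=C/C2(C)C=CC(=O)O2)c1OC` differs from compound 2 by hydrogen in place of methyl on an oxygen on an aromatic ring, or methoxy to hydroxy. Going by the values given here, no measured step shows this change, so the evidence is indirect. The step of a 2.5-fold higher number from compound 1 to compound 2 (0.40 log units; beyond the scatter) suggests only that altering the substitution of this aromatic ring can shift the number by a modest amount. With compound 2 at the upper end of the numbers, at 110000 nM, a modest move toward a lower number is expected in this assay, although a result within the scatter would not be surprising. The estimated step is a 1.7-fold lower number from compound 2 to compound 3 (0.23 log units; within the scatter). For compound 3 the expected value is 65000 nM, with an estimated range from 25000 nM to 160000 nM.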

Compound 3, concentration for total growth inhibition: 45300 nM
The estimate for compound 3 lay 1.4-fold (0.16 log units) above the measured number; low and high end bracket the measured number.
By their numbers in this assay, from the lowest: compounds 1 and 3 (each within the scatter of the next); then compound 2.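

In this assay, the change of methoxy to hydroxy, hydrogen in place of methyl on an oxygen on an aromatic ring, gives a 2.4-fold lower number from compound 2 to compound 3 (0.39 log units; beyond the scatter). For the compounds shown here, no earlier step touched such an oxygen, and this one shows that the number responds to losing that methyl as well as to adding a methoxy on an aromatic carbon: the earlier step, a 2.5-fold higher number from compound 1 to compound 2 (0.40 log units; beyond the scatter), ran toward weaker inhibition of growth, whereas this modest step runs toward stronger inhibition. No available evidence accounts for this shift.

The compounds shown leave open whether the same change would give a step of similar size and direction on another substitution pattern of the aromatic ring, since it is seen here in a single pair. They also leave open how the number would respond to other replacements at this place, such as an ethyl on the oxygen, or an amine or a carboxylic acid in place of the hydroxy.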